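Trading a difluorophenyl for a methoxyphenyl: expected lipophilicity

The compounds below may be only part of what the source reports. "The series", "measured", "known", "first", "only" and "open" are said of these compounds alone.

Measured compounds, in a physicochemical assay for lipophilicity; on this read-out lower numbers stand for lower lipophilicity and higher numbers for higher lipophilicity:
Compound 1 `COc1ccc(C2C[C@@]3(ON2c2ccccc2)C(=O)O[C@@H]2[C@H]3CC[C@H](C)[C@]3(O)C=CC(=O)[C@@]23C)cc1` gives 3.25.
Compound 2 `Cc1ccc(C2C[C@@]3(ON2c2ccccc2)C(=O)O[C@@H]2[C@H]3CC[C@H](C)[C@]3(O)C=CC(=O)[C@@]23C)cc1` gives 3.64.
Compound 3 `C[C@H]1CC[C@@H]2[C@@H](OC(=O)[C@]23CC(c2c(F)cccc2F)N(c2ccccc2)O3)[C@]2(C)C(=O)C=C[C@@]12O` gives 3.42.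

Compound 3 stands second highest of these three numbers. Its nearest neighbour is compound 1, with a number 0.17 log units higher from compound 1 to compound 3 (within the scatter), and the furthest is compound 2, with a number 0.22 log units lower from compound 2 to compound 3 (within the scatter); both of these steps are within the scatter, so the three compounds cannot be ordered by these numbers. Among the measured compounds shown here, the only step beyond the scatter among them is a number 0.39 log units higher from compound 1 to compound 2 (beyond the scatter), where a methyl replaces a methoxy on the aromatic ring.

Compound 4 `COc1cccc(C2C[C@@]3(ON2c2ccccc2)C(=O)O[C@@H]2[C@H]3CC[C@H](C)[C@]3(O)C=CC(=O)[C@@]23C)c1` has not yet been measured. It differs from compound 3 in one place: 3-methoxyphenyl in place of 2,6-difluorophenyl on a saturated ring carbon. For the measured compounds named here, the steps that bear on this change are the two that lead into compound 3, in which the 2,6-difluorophenyl replaced a 4-methoxyphenyl or a 4-methylphenyl on the same saturated ring carbon; neither moved the read-out beyond the scatter. Compound 1, which also carries a methoxyphenyl, is the closest comparison, and its step to compound 3 was small. Compound 4 is therefore expected to sit close to compound 3, with an expected step of a number 0.12 log units lower from compound 3 to compound 4 (within the scatter), within the scatter. The estimate for compound 4 in this assay is 3.3, in a range from 3 to 3.6.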

Compound 4, partition coefficient: 3.25
Beside the measured number, compound 4's estimate is 0.05 log units above it, within the range that was stated.
By their numbers in this assay, from the lowest: compounds 1, 4, 3 and 2 (each within the scatter of the next, the first and the last beyond it).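

On this saturated ring carbon, replacing 4-methoxyphenyl with 3-methoxyphenyl gives no change at the digits printed from compound 1 to compound 4 (within the scatter) in this assay so this read-out does not tell these two methoxyphenyl groups apart. Replacing 2,6-difluorophenyl with 3-methoxyphenyl gives a number 0.17 log units lower from compound 3 to compound 4 (within the scatter) so this exchange of two fluorine atoms for a carbon and an oxygen also leaves the two compounds unresolved. The 3-methoxyphenyl compound does separate from the 4-methylphenyl compound, with a number 0.39 log units lower from compound 2 to compound 4 (beyond the scatter) and thus both methoxyphenyl compounds now stand apart from compound 2, while compound 3 lies within the scatter of all the others.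

The compounds shown leave open whether a different kind of group on this carbon, such as an amine or a carboxylic acid, would shift the read-out beyond the scatter from the methoxyphenyl compounds. Nothing shown gives a reason for these numbers.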